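A few compounds are considered here, and "the series" means these few. Any claim that something is new, unique, unknown or untested is made for them only; others in the source may bear on it.

Measured so far:
compound 1 `O=C1c2c[n+]([O-])c3ccccc3c2C(=O)c2c1c1ccccc1n2Cc1cn(CC(O)CO)nn1`: 440 nM
compound 2 `CC1(C)OC[C@@H](Cn2cc(Cn3c4c(c5ccccc53)C(=O)c3c[n+]([O-])c5ccccc5c3C4=O)nn2)O1`: 450 nM
compound 3 `CC1(C)OC[C@H](Cn2cc(Cn3c4c(c5ccccc53)C(=O)c3c[n+]([O-])c5ccccc5c3C4=O)nn2)O1`: 180 nM

All three were tested in a functional assay on A-375 cells (Homo sapiens) for cytotoxicity, read by MTT assay, with a stated time of 72 h; a higher number here means a weaker inhibitor, a lower number a stronger inhibitor. Compound 1 gives the second highest of the three numbers. The step of a 1.0-fold higher number from compound 1 to compound 2 (0.01 log units; within the scatter) lies within the scatter, while a 2.4-fold lower number from compound 1 to compound 3 (0.39 log units; beyond the scatter) and a 2.5-fold lower number from compound 2 to compound 3 (0.40 log units; beyond the scatter) are modest; the last of these rests on configuration alone because of the fact that compounds 2 and 3 differ only in the configuration as drawn.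

Compound 4 `CN1CCN(CCCCn2c3c(c4ccccc42)C(=O)c2c[n+]([O-])c4ccccc4c2C3=O)CC1` is not yet measured. Its change from compound 1 is 3-(4-methylpiperazin-1-yl)propyl in place of 1-(2,3-dihydroxypropyl)-1H-1,2,3-triazol-4-yl on a saturated chain carbon bound to an aromatic nitrogen. Within the data shown here, none of the measured steps swaps this part of the chain in the same way, so they bear only loosely: they show that changes at this saturated chain carbon have shifted the number by modest amounts at most. Compound 4 is therefore expected near 300 nM, in the range 100 nM to 900 nM. The expected step is a 1.5-fold lower number from compound 1 to compound 4 (0.17 log units; within the scatter), likely small.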

Compound 4, half-maximal inhibitory concentration: 30 nM
For compound 4 the middle estimate is 10-fold (1.00 log units) above the measured one, outside the stated range (below it).
By their numbers in this assay, from the lowest: compound 4; then compound 3; then compounds 1 and 2 (each within the scatter of the next).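

In this assay, among these compounds, the group on the saturated chain carbon bound to an aromatic nitrogen matters far more than the earlier compounds suggested: putting 3-(4-methylpiperazin-1-yl)propyl in place of 1-(2,3-dihydroxypropyl)-1H-1,2,3-triazol-4-yl gives a 15-fold lower number from compound 1 to compound 4 (1.17 log units; beyond the scatter). Earlier changes here moved the number only modestly, so this place can carry a large shift. Nothing measured here explains why this swap has so large an effect.

Going by these compounds, this swap replaces the ring and the chain together, so which part counts remains open. A morpholine ring or a dimethylamino group on the same butyl chain would help separate the two.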